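Methoxyphenyl amide positional swap on the shared core

This account rests on a few compounds, and the source may have more. Where it says the series, first, only, none or still open, it means among the compounds named here.

Among the compounds with values here, compound 1 `COc1cccc(C(=O)Nc2cc(Sc3ncn[nH]3)c(O)c3ccccc23)c1` carries the only numerical reading in the set: in a functional assay on PC-3 cells (Homo sapiens) for antiproliferative activity, read by MTT assay, with a stated time of 48 h (on this read-out higher numbers stand for weaker inhibition and lower numbers for stronger inhibition), compound 1 gives 42100 nM. Compound 2 `O=C(Nc1cc(Sc2ncnc3nc[nH]c23)c(O)c2ccccc12)c1ccc([N+](=O)[O-])cc1` returns only a limit of the assay, > 100000 nM. Compound 3 `COc1ccc(/C=C/C(=O)Nc2cc(Sc3ncn[nH]3)c(O)c3ccccc23)cc1OC` likewise returns only a limit, > 100000 nM. Within the data shown here, two of the three readings therefore sit at the limit of > 100000 nM in this assay, at which 2 of the 3 values shown sit, and compound 1 is the one member of the set with a measurable number, standing below that limit.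

Compound 4 `COc1ccc(C(=O)Nc2cc(Sc3ncn[nH]3)c(O)c3ccccc23)cc1` differs from compound 1 in a single respect: 4-methoxyphenyl in place of 3-methoxyphenyl on a carbonyl carbon. Among the measured compounds shown here, no pair of measured compounds differs in one place, so no measured step guides this change. Since the amide aryl group keeps its size and its single methoxy substituent, a step in this assay of no more than the usual scatter is expected, in either direction, with some chance that the reading lands at the limit. The expected step from compound 1 to compound 4 is a 1.1-fold higher number from compound 1 to compound 4 (0.03 log units; within the scatter). Compound 4 is accordingly estimated at 45000 nM, within a range of 15000 nM to 100000 nM.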

Compound 4, half-maximal inhibitory concentration: > 100000 nM
Compound 4: no number, only a limit; the forecaster's own chance of this, stated with the estimate: 30%; at least 2.2-fold (0.34 log units) between middle value and limit.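

In this assay, within the data shown here, 4-methoxyphenyl in place of 3-methoxyphenyl on a carbonyl carbon is the first one-place change that can be read, and it gives an at least 2.3-fold higher number from compound 1 to compound 4 (0.37 log units; beyond the scatter). Compound 4 gives > 100000 nM, which is a limit and not a number. The two compounds have the same atoms, joined differently, so on this amide aryl group the place of the methoxy alone separates a measurable reading from a limit, and compound 1 remains the only compound with a number: the limit of > 100000 nM in this assay, at which 3 of the 4 values shown sit.

On these data alone, how far compound 4 actually lies from compound 1 stays open. Also open, as far as these compounds go, is whether an amine or a carboxylic acid in place of the methoxy on this aryl group would give a measurable reading.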